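Sulfonyl aryl swap on a shared core, DU-145 cells

The source may hold more compounds than are shown below. What is called first, only, known or untested is meant among the compounds shown, and "the series" means these compounds.

Measured so far:
compound 1, `Cn1c(=O)c(S(=O)(=O)c2ccc(F)cc2F)cc2cnc(Nc3ccc4occc4c3)nc21`, 15000 nM
compound 2, `Cn1c(=O)c(S(=O)(=O)c2ccc(C(=O)O)cc2)cc2cnc(Nc3ccc4[nH]ccc4c3)nc21`, 10000 nM
compound 3, `Cn1c(=O)c(S(=O)(=O)c2ccccc2)cc2cnc(Nc3ccc4ncccc4c3)nc21`, 50000 nM

All three were tested in a functional assay on DU-145 cells (Homo sapiens) for inhibition, read by trypan blue exclusion, with a stated time of 72 h; on this read-out higher numbers stand for weaker inhibition and lower numbers for stronger inhibition. Compound 2 has the lowest number of the three, at 10000 nM. Compound 1, at 15000 nM, sits within the usual scatter of compound 2, so these two cannot be told apart on these numbers. Compound 3, at 50000 nM, lies beyond that scatter, so it is a weaker inhibitor than compound 2.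

Compound 4, `Cn1c(=O)c(S(=O)(=O)c2ccc(F)cc2N)cc2cnc(Nc3ccc4[nH]ccc4c3)nc21`, has not yet been measured. It differs from compound 2 in one place: 2-amino-4-fluorophenyl in place of 4-carboxyphenyl on a sulfonyl sulfur

For the measured compounds named here, no measured pair shows this exact change, so its size is unknown. The three compounds carry three different groups on the sulfonyl sulfur and three different amine-side rings, and their numbers span a modest range, so a small step in either direction, or none beyond the scatter, is expected: a 1.1-fold lower number from compound 2 to compound 4 (0.05 log units; within the scatter). Compound 4 is therefore estimated at 9000 nM, with a range from 2500 nM to 35000 nM.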

Compound 4, half-maximal inhibitory concentration: 3000 nM
Estimate against measurement, compound 4: 3.0-fold (0.48 log units) above, within the range that was stated.
By their numbers in this assay, from the lowest: compound 4; then compounds 2 and 1 (each within the scatter of the next); then compound 3.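

In this assay, for the compounds shown here, the swap to 2-amino-4-fluorophenyl in place of 4-carboxyphenyl gives the first reading of a single change in this set (a 3.3-fold lower number from compound 2 to compound 4 (0.52 log units; beyond the scatter)), and it shows that the group on the sulfonyl sulfur can move the number beyond the scatter while the rest of the molecule stays fixed. Both groups have one six-membered aromatic ring of carbon only, so the step comes with a change in what that ring carries, not with a change of the ring itself. Nothing measured here explains why the number moves.

From the compounds shown here alone, the amine and the fluorine enter together as the carboxylic acid leaves, so the share of each in the step stays unknown. A ring carrying only the amine or only the fluorine on this core, or an amide in place of the carboxylic acid, would help to separate them.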